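The source may report more compounds than this note shows. Statements on the series, on what has been measured and on what is new or still open speak of the compounds shown alone.

Working notes on the series.

Two compounds carry numbers in a physicochemical assay, read by spectrophotometry, with a stated time of 10 min; a higher number here means a weaker inhibitor, a lower number a stronger inhibitor. Compound 1, `COC(=O)C1=CO[C@@H](O[C@@H]2O[C@H](CO)[C@@H](O)[C@H](O)[C@H]2O)[C@H]2[C@@H]1[C@H](O)C[C@]2(C)OC(C)=O`, gives 110 ug/mL in this assay. Compound 2, `COC(=O)C1=CO[C@@H](O[C@@H]2O[C@H](CO)[C@@H](O)[C@H](O)[C@H]2O)[C@H]2[C@@H]1[C@H](OC(C)=O)C[C@]2(C)O`, gives 286 ug/mL in this assay, the higher of the two numbers, and the gap between compound 2 and compound 1 lies beyond the usual scatter. Going by the values given here, no pair among the measured compounds differs in a single place, so no measured step is available to lean on.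

Compound 3, `COC(=O)C1=CO[C@@H](O[C@@H]2O[C@H](CO)[C@@H](O)[C@H](O)[C@H]2O)[C@H]2[C@@H]1[C@H](O)C[C@]2(C)O`, is the next member to be run in this assay. It follows from compound 2 by one change: hydrogen in place of acetyl on an oxygen on a saturated carbon. The result is the free diol shared by neither compound 1 nor compound 2, each of which carries one acetyl.

With compound 2 sitting on the weaker side of the pair and compound 1, also a single acetyl derivative, on the stronger side, the step from compound 2 to compound 3 is expected to be modest and toward a lower number, a 1.6-fold lower number from compound 2 to compound 3 (0.20 log units; within the scatter), not far past the scatter. For compound 3 the expected value in this assay is 180 ug/mL, with a range from 90 ug/mL to 380 ug/mL.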

Compound 3, half-maximal inhibitory concentration: 97.5 ug/mL
Estimate against measurement, compound 3: 1.8-fold (0.27 log units) above; the range from low to high includes it.
By their numbers in this assay, from the lowest: compounds 3 and 1 (each within the scatter of the next); then compound 2.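

The same change, hydrogen in place of acetyl, now reads differently at the two acetylated oxygens: in this assay compound 3 gives 97.5 ug/mL and the acetoxy to hydroxy step at the acetyl of compound 2 is a 2.9-fold lower number from compound 2 to compound 3 (0.47 log units; beyond the scatter). At the acetyl of compound 1 the same change gives a 1.1-fold lower number from compound 1 to compound 3 (0.05 log units; within the scatter), so on these two steps acetyl costs inhibition at the first place and has no readable effect at the second, which a comparison of compound 1 with compound 2 alone could not separate. Nothing measured on these compounds accounts for the difference between the two places.

The compounds shown leave open whether the penalty at the oxygen on a saturated carbon belongs to acetyl alone or would also appear with a longer acyl chain such as butanoyl, a benzoyl ester or a methyl ether on that oxygen. They also leave open how a compound carrying acetyl on both oxygens would read against these two single steps.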